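Compound 2 to compound 3: methyl for chloro

A few compounds are considered here, and "the series" means these few. Any claim that something is new, unique, unknown or untested is made for them only; others in the source may bear on it.

In a functional assay on thoracic aorta (Rattus norvegicus, strain Wistar), with a stated time of 15 min (on this read-out higher numbers stand for an effect only at larger amounts of compound and lower numbers for an effect already at smaller amounts), compound 1 (`Cc1ccc(S(=O)(=O)N(C)C(=O)NC(C)c2cc(Br)ccc2OC(C)C)cc1`) gives 34700 nM and compound 2 (`CC(C)Oc1ccc(Br)cc1C(C)NC(=O)NS(=O)(=O)c1ccc(Cl)cc1`) gives 122000 nM as the higher of the two numbers, a gap beyond the usual scatter. Compound 3 (`Cc1ccc(S(=O)(=O)NC(=O)NC(C)c2cc(Br)ccc2OC(C)C)cc1`) is still unmeasured and differs from compound 2 in one place (methyl in place of chloro on an aromatic carbon): methyl in place of chloro on an aromatic carbon, para to a large group, turning 4-chlorophenyl into 4-methylphenyl. Among the measured compounds shown here, no measured pair shows this change on its own, so the expectation rests on the two values alone and stays wide. The expected move is small, a 1.5-fold lower number from compound 2 to compound 3 (0.18 log units; within the scatter) in this assay and so none beyond the scatter. For the measured compounds named here, compound 1 at 34700 nM is the only lower number available as a guide. The estimate for compound 3 is 80000 nM with an expected range from 28000 nM to 230000 nM on this read-out.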

Compound 3, half-maximal effective concentration: 61800 nM
Estimate against measurement, compound 3: 1.3-fold (0.11 log units) above, within the range that was stated.
By their numbers in this assay, from the lowest: compounds 1, 3 and 2 (each within the scatter of the next, the first and the last beyond it).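

In this assay, the change from 4-chlorophenyl to 4-methylphenyl gives a 2.0-fold lower number from compound 2 to compound 3 (0.30 log units; within the scatter), so methyl and chloro on this aromatic carbon, para to a large group, cannot be told apart on this read-out. Hydrogen in place of methyl on the amide-type nitrogen gives a 1.8-fold higher number from compound 1 to compound 3 (0.25 log units; within the scatter), so that exchange also stays within the scatter, and neither single change separates its pair of compounds. No measurement at hand offers an explanation for either result.

The compounds shown leave open how an amine or a carboxylic acid on this aromatic carbon would read in this assay. They also leave open whether a longer chain on the amide-type nitrogen would stay within the scatter of compound 3.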